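Pyrazolyl enones: step from compound 3 to difluorophenyl analogue

This account rests on a few compounds, and the source may have more. Where it says the series, first, only, none or still open, it means among the compounds named here.

Measured so far:
- compound 1 `COc1cc(-c2cc(/C=C/C(=O)c3ccc(N)cc3)[nH]n2)cc(OC)c1OC`: -64%
- compound 2 `COc1cc(-c2cc(/C=C/C(=O)c3ccc(Cl)c(Cl)c3)[nH]n2)cc(OC)c1OC`: 61%
- compound 3 `COc1ccc(C(=O)/C=C/c2cc(-c3cc(OC)c(OC)c(OC)c3)n[nH]2)cc1`: -44%

All three share one core and differ only in the aryl group on the carbonyl carbon. In a functional assay on M14 cells (Homo sapiens) for cytotoxicity, read by sulforhodamine B assay, with a stated time of 48 h, tested at 10 uM (on this read-out lower numbers stand for a stronger effect and higher numbers for a weaker effect at the one concentration tested), compound 3 gives -44%, the second highest of the three numbers; its nearest neighbour is compound 1, and a number 20 percentage points higher from compound 1 to compound 3 (beyond the scatter). The furthest is compound 2, with a number 105 percentage points lower from compound 2 to compound 3 (beyond the scatter). The other measured step, a number 125 percentage points higher from compound 1 to compound 2 (beyond the scatter), points the same way as the dihalogenated aryl.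

Compound 4 `COc1cc(-c2cc(/C=C/C(=O)c3ccc(F)c(F)c3)[nH]n2)cc(OC)c1OC` has not yet been measured. Its change from compound 3 is 3,4-difluorophenyl in place of 4-methoxyphenyl on a carbonyl carbon. The step that bears on it most directly is a number 105 percentage points lower from compound 2 to compound 3 (beyond the scatter), which is the same carbonyl-carbon exchange run the other way with a different halogen pair. Among the compounds with values here, no step with a difluorophenyl is on hand, so the size carries over from the dichlorophenyl step with some uncertainty. A large step upward in this assay is therefore expected, of about a number 84 percentage points higher from compound 3 to compound 4 (beyond the scatter).

On that basis compound 4 is estimated at 40% in this assay, with a range from -5% to 80%.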

Compound 4, a percentage reported as activity, at one concentration (the size of the read-out at that concentration, not a potency): 3%
For compound 4 the middle estimate is 37 percentage points above the measured one, and the stated range covers the measured number.
By their numbers in this assay, from the lowest: compound 1; then compound 3; then compound 4; then compound 2.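

Notes on the aryl group on the carbonyl carbon: in this assay the halogen pair itself matters, since keeping the dihalogenated pattern but exchanging chlorine for fluorine still gives a number 58 percentage points lower from compound 2 to compound 4 (beyond the scatter). Both dihalogenated aryls now read higher than the two aryls with a single amino or methoxy substituent, with no exception among the four compounds: the difluorophenyl gives a number 47 percentage points higher from compound 3 to compound 4 (beyond the scatter) and a number 67 percentage points higher from compound 1 to compound 4 (beyond the scatter), so compound 4 at 3% occupies the middle of the span rather than either end. Nothing on hand accounts for this order or for the gap between the two halogen pairs.

Left open is whether the upward shift in this assay needs two halogens or follows from one, which an unsubstituted phenyl or a phenyl carrying a single fluorine or a single chlorine would help to settle. Also open, going by these compounds, is how a different kind of group on the carbonyl carbon, such as a dimethylamino-substituted phenyl, a hydroxyphenyl or a carboxylic acid on the aryl, would sit relative to the aminophenyl and methoxyphenyl compounds.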